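Swapping Methoxy for Bromo on the Aryl Ring

The source may report more compounds than this note shows. Statements on the series, on what has been measured and on what is new or still open speak of the compounds shown alone.

For the measured compounds named here, compound 1 `COc1ccc(/C(Cl)=C/C=C(\C#N)C(=O)c2c(C)[nH]c3ccccc23)cc1` gives 34.2% in a functional assay for inhibition, with a stated time of 30 min, tested at 1 mM (on this read-out lower numbers stand for less inhibition and higher numbers for more inhibition at the one concentration tested (going by the name of the read-out)), the higher of the two numbers measured so far. Its nearest neighbour, compound 2 `COc1ccc(/C(Cl)=C/C=C(\C#N)C(=O)c2c(C)[nH]c3ccccc23)cc1OC`, gives 22.4% in this assay. Going by the values given here, the only measured step, a number 11.8 percentage points lower from compound 1 to compound 2 (beyond the scatter), concerns a different position and does not speak to the change considered here. Compound 3 `Cc1[nH]c2ccccc2c1C(=O)/C(C#N)=C/C=C(\Cl)c1ccc(Br)cc1` differs from compound 1 by bromo in place of methoxy on an aromatic carbon. Among the compounds with values here, no measured step bears on this change, so the expected step is estimated as a number 0.2 percentage points lower from compound 1 to compound 3 (within the scatter). Compound 3 is therefore estimated at 34%, with a range from 20% to 48%.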

Compound 3, a percentage reported as inhibition, at one concentration (the size of the read-out at that concentration, not a potency): 15.8%
Beside the measured number, compound 3's estimate is 18.2 percentage points above it; the measured number lies below the stated range.
By their numbers in this assay, from the lowest: compounds 3 and 2 (each within the scatter of the next); then compound 1.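

The change from 4-methoxyphenyl to 4-bromophenyl gives a number 18.4 percentage points lower from compound 1 to compound 3 (beyond the scatter) in this assay and so shows that the group para to a large group affects this read-out. For the compounds shown here, the earlier step added a methoxy elsewhere on the ring and left this one in place, so only this step tests the position itself. Nothing available accounts for the drop.

Only these two groups are shown at this place. Going by these compounds, whether a hydroxy, an amino or a fluoro group would match compound 1 or fall to the level of compound 3 stays open.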